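The source may hold more compounds than are shown below. What is called first, only, known or untested is meant among the compounds shown, and "the series" means these compounds.

Three compounds in this set share one core and differ only in the aromatic group attached to the carbon with a double bond to nitrogen. Compound 1 `COc1ccc(O)c(/C=N/NC(=O)c2ccc(-c3nc4ccccc4s3)cc2)c1` carries a 2-hydroxy-5-methoxyphenyl at that carbon. In an assay on isolated protein for inhibition of Maltase-glucoamylase (Homo sapiens), with a stated time of 15 min (on this read-out lower numbers stand for stronger inhibition and higher numbers for weaker inhibition), compound 1 gives 6500 nM. Compound 2 `O=C(N/N=C\c1ccccn1)c1ccc(-c2nc3ccccc3s2)cc1` gives 10200 nM in this assay, and this number sits within the usual scatter of the number for compound 1, so the two cannot be told apart. Compound 3 `COc1ccc(/C=N/NC(=O)c2ccc(-c3nc4ccccc4s3)cc2)cc1OC` is recorded in this assay as "not active" (no number reported), with no number given. Among the two compounds with a number, compound 1 thus has the lower one, though only by an amount that repeated measurement could erase.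

Compound 4 `O=C(N/N=C/c1cccc(O)c1)c1ccc(-c2nc3ccccc3s2)cc1` is the next compound. Its change from compound 1 is 3-hydroxyphenyl in place of 2-hydroxy-5-methoxyphenyl on a carbon with a double bond to nitrogen. Going by the values given here, no pair of measured compounds shows this exact step, so its size must be guessed. Because compound 1 gives 6500 nM while compound 3, which has no hydroxyl on that ring, is recorded as "not active" (no number reported), keeping a hydroxyl seems worth something, and compound 4 is expected to stay in the same broad region, with a step of a 1.4-fold higher number from compound 1 to compound 4 (0.14 log units; within the scatter) toward a slightly higher number. The estimate for compound 4 in this assay is 9000 nM, within a range from 3000 nM to 30000 nM.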

Compound 4, half-maximal inhibitory concentration: 9210 nM
The estimate for compound 4 lay 1.0-fold (0.01 log units) below the measured number, and the stated range covers the measured number.
By their numbers in this assay, from the lowest: compounds 1, 4 and 2 (each within the scatter of the next).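

Exchanging 2-hydroxy-5-methoxyphenyl for 3-hydroxyphenyl on the carbon with a double bond to nitrogen gives a 1.4-fold higher number from compound 1 to compound 4 (0.15 log units; within the scatter) in this assay, so this position tolerates a group with fewer heavy atoms and without the methoxy, with no change that can be told from scatter. Compound 4 also cannot be told apart from compound 2, with a 1.1-fold lower number from compound 2 to compound 4 (0.04 log units; within the scatter), which means that an all-carbon aromatic ring carrying a hydroxyl and an aromatic ring with a hetero atom read the same here. A hydroxyl on the ring is therefore not needed for a measurable number: compound 1 and compound 4 carry one and give numbers, compound 2 has none and still gives a number, and compound 3 has none and gives no number.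

Still open, as far as these compounds go, is whether a different group on this carbon, such as a phenyl bearing an amine or a carboxylic acid, or a longer chain in place of the ring, would move the number beyond the scatter. Nothing available explains why these groups read alike.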